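A few compounds are considered here, and "the series" means these few. Any claim that something is new, unique, unknown or untested is made for them only; others in the source may bear on it.

Measured compounds in this series:
compound 1, `COc1ccc([C@H]2CC(=O)N(Cc3cccc(N)c3)C2)cc1OC1CCCC1`: > 10000 nM
compound 2, `COc1ccc([C@H]2CC(=O)N(c3ccc(N)cc3)C2)cc1OC1CCCC1`: > 10000 nM

In a functional assay on HEK293 cells (Homo sapiens) for cytotoxicity (on this read-out lower numbers stand for higher toxicity in this test and higher numbers for lower toxicity in this test), compound 1 gives > 10000 nM, which is a limit of the assay rather than a number. In this assay compound 2 likewise gives > 10000 nM, again a limit and not a number. Among the compounds with values here, compound 2 therefore stands at the limit, and the single step between measured compounds, a step that the two limits leave unreadable from compound 1 to compound 2, cannot be read in size or direction; the only evidence on the measured step is the limit of > 10000 nM in this assay, at which 2 of the 2 values shown sit.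

Compound 3, `COc1ccc([C@H]2CC(=O)N(c3ccccc3C(F)(F)F)C2)cc1OC1CCCC1`, differs from compound 2 by 2-(trifluoromethyl)phenyl in place of 4-aminophenyl on an amide-type nitrogen in a ring. No measured step touches a 2-(trifluoromethyl)phenyl on this amide-type nitrogen in a ring, so the change from compound 2 to compound 3 has no precedent in the numbers shown. Within the data shown here, the only guide is that both measured values sit at the limit, which gives no readable step to carry over; the step that the limit leaves unreadable from compound 2 to compound 3 is therefore expected to be none beyond the scatter, with compound 3 most likely again reported only as a limit. Compound 3 is estimated in this assay at 15000 nM, within a range of 5000 nM to 50000 nM.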

Compound 3, half-maximal cytotoxic concentration: > 10000 nM
Compound 3 gave a limit, no number; the forecaster's own chance of this, stated with the estimate: 75%; the middle value is on the limit's open side.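

Compound 3 in this assay gives > 10000 nM, a limit and not a number. The steps linking compound 3 to compound 1 and compound 2 therefore cannot be read: the limit of > 10000 nM in this assay, at which 3 of the 3 values shown sit.

The compounds shown leave open where the half-maximal cytotoxic concentration of each lies, and whether the groups on the amide-type nitrogen in a ring differ at all in this assay.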